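The compounds below may be only part of what the source reports. "The series", "measured", "known", "first", "only" and "open" are said of these compounds alone.

The measured compounds in an assay on isolated protein for inhibition of protein kinase C delta type (Homo sapiens), read by TR-FRET, with a stated time of 2 h; a lower number here means a stronger inhibitor, a higher number a weaker inhibitor:

Compound 1, `N#Cc1cnc(NCc2cnccc2C(F)(F)F)cc1N[C@H]1CC[C@H](O)CC1`, gives 6500 nM.
Compound 2, `N#Cc1cnc(NCc2ccccc2C(F)(F)F)cc1N[C@H]1CC[C@H](O)CC1`, gives only a limit, > 10000 nM; it sits at the limit of > 10000 nM in this assay, at which 1 of the 3 values shown sits.
Compound 3, `CO[C@H]1CC[C@@H](Nc2cc(NCc3cnccc3C(F)(F)F)ncc2C#N)CC1`, gives 5000 nM.

Among the two numbers shown in this assay, compound 1 has the highest; its nearest neighbour is compound 3, and the step of a 1.3-fold lower number from compound 1 to compound 3 (0.11 log units; within the scatter) lies within the scatter. Compound 2 is known only as a limit, not as a number.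

Compound 4, `CO[C@H]1CC[C@H](CNc2cc(NCc3cnccc3C(F)(F)F)ncc2C#N)CC1`, has not been measured in this assay. It differs from compound 1 in one place: (4-methoxycyclohexyl)methyl in place of 4-hydroxycyclohexyl on a nitrogen on an aromatic ring. Within the data shown here, the only measured step that bears on this change is the one from compound 1 to compound 3, which exchanges the 4-hydroxycyclohexyl for a 4-methoxycyclohexyl and moves the number by a 1.3-fold lower number from compound 1 to compound 3 (0.11 log units; within the scatter), within the scatter. Among the measured compounds shown here, no measured pair tells what the added methylene in (4-methoxycyclohexyl)methyl does, so that part of the change is untested here. On the evidence of compound 3, the expectation for compound 4 in this assay is a step of about a 1.1-fold lower number from compound 1 to compound 4 (0.03 log units; within the scatter) from compound 1, that is, no change beyond the scatter, with a wide band to allow for the untested spacer. Compound 4 is thus estimated at 6000 nM, with a range from 2000 nM to 20000 nM.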

Compound 4, half-maximal inhibitory concentration: > 10000 nM
Compound 4: only a limit was reported (the forecaster's own chance of this, stated with the estimate: 30%); middle value at least 1.6-fold (0.22 log units) away from the limit.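

Compound 4 gives only a limit in this assay, > 10000 nM, and not a number: the limit of > 10000 nM in this assay, at which 2 of the 4 values shown sit.

Among these compounds, the first step that isolates the added methylene is an at least 2.0-fold higher number from compound 3 to compound 4 (0.30 log units; that floor lies within the scatter), and the full exchange on this nitrogen reads an at least 1.5-fold higher number from compound 1 to compound 4 (0.18 log units; that floor lies within the scatter). Both floors lie within the scatter, so neither step fixes a real loss or its size, but the data now show that moving the ring one methylene further out gives no lower number in this assay, a point that the exchange of hydroxy for methoxy alone could not show.

The compounds shown leave open how a (4-hydroxycyclohexyl)methyl group would read, and so whether the spacer has the same outcome when the free hydroxyl is kept. They also leave open whether a smaller ring such as cyclobutyl, or an amine or a carboxylic acid in place of the methoxy on the (4-methoxycyclohexyl)methyl group, would give a number in this assay rather than a limit.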